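Swapping the dichlorothiophene for a carbamoyl-hydroxyphenyl

This account rests on a few compounds, and the source may have more. Where it says the series, first, only, none or still open, it means among the compounds named here.

This series shares a core in which a methylsulfonylbenzyl group hangs from a fused two-ring system, with an aryl group on the carbon that carries a double bond to nitrogen. Compound 1 `CS(=O)(=O)c1ccc(Cc2nnc3n2N=C(c2ccccc2)CS3)cc1` carries a plain phenyl there, and in a functional assay on RAW264.7 cells (Mus musculus) for cytotoxicity, read by MTT assay, with a stated time of 48 h, tested at 12.5 uM (on this read-out lower numbers stand for a weaker effect and higher numbers for a stronger effect at the one concentration tested), compound 1 gives 42%. Compound 2 `CS(=O)(=O)c1ccc(Cc2nnc3n2N=C(c2cc(Cl)sc2Cl)CS3)cc1` carries a 2,5-dichlorothiophen-3-yl instead, and in this assay compound 2 is reported as "not active" (no number reported), so no single number stands for it.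

Compound 3 `CS(=O)(=O)c1ccc(Cc2nnc3n2N=C(c2ccc(O)c(C(N)=O)c2)CS3)cc1` is the next step: 3-carbamoyl-4-hydroxyphenyl in place of 2,5-dichlorothiophen-3-yl on a carbon with a double bond to nitrogen. Among the compounds with values here, since compound 2 offers no number, no size can be computed for the step to compound 3, and the only anchor with a value is compound 1 with its 42%, which also carries a six-membered carbon ring at this place. Somewhere between these two neighbours is where the read-out in this assay for compound 3 is therefore expected to land, estimated at 25% with a range from 0% to 55%, and it may again be reported only as inactive.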

Compound 3, a percentage reported as activity, at one concentration (the size of the read-out at that concentration, not a potency): 24.8%
Estimate against measurement, compound 3: 0.2 percentage points above, and the stated range covers the measured number.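

Compound 3 shows that this place, on a carbon with a double bond to nitrogen, can carry a 3-carbamoyl-4-hydroxyphenyl and still return a number in this assay, with a number 17.2 percentage points lower from compound 1 to compound 3 (beyond the scatter). The step from compound 2 to compound 3 cannot be read, as compound 2 has no number, so the printed values show only that a reported percentage replaces a "not active" label. Nothing available accounts for the lower read-out relative to the plain phenyl.

The carbamoyl and the hydroxy group enter together, so the compounds shown do not tell which of them goes with the step. A phenyl carrying only one of the two, or a carboxylic acid or an amine in place of the carbamoyl, remains outside these compounds.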